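Estimating a shortened amine side chain on the shared dioxolane core

This account rests on a few compounds, and the source may have more. Where it says the series, first, only, none or still open, it means among the compounds named here.

Compound 1 `CCC[C@H](N)[C@H]1COC(c2ccccc2)(c2ccccc2)O1`: 3450 nM
Compound 2 `CCC[C@H](NC)[C@H]1COC(c2ccccc2)(c2ccccc2)O1`: 7000 nM

Of the compounds shown here, two have been measured in a functional assay (brain) for displacement of a labelled ligand, with Rattus norvegicus as the target; on this read-out lower numbers stand for stronger inhibition and higher numbers for weaker inhibition. Among the compounds with values here, compound 2 stands at the higher of the two numbers; its only neighbour is compound 1, and the step of a 2.0-fold higher number from compound 1 to compound 2 (0.31 log units; beyond the scatter) separates them. Within the data shown here, that is the one measured step, and it involves only the substituent on the amine nitrogen.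

Compound 3 `CCNC[C@H]1COC(c2ccccc2)(c2ccccc2)O1` has not been measured. It differs from compound 2 as follows: (ethylamino)methyl in place of 1-(methylamino)butyl on a saturated ring carbon. Among the measured compounds shown here, no measured pair shows what happens when the butyl side chain is cut back to a methylene bearing an ethylamino group, so the step from compound 1 to compound 2 bears on it only loosely, by showing that a change at the amine nitrogen shifted the number modestly. The expected step is a 1.4-fold higher number from compound 2 to compound 3 (0.15 log units; within the scatter), towards a weaker result but with wide uncertainty. Compound 3 is therefore estimated at 10000 nM, within the range 3000 nM to 35000 nM.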

Compound 3, inhibition constant: 8400 nM
Compound 3: the middle estimate sits 1.2-fold (0.08 log units) above what was measured; the measured number falls inside the stated range.
By their numbers in this assay, from the lowest: compound 1; then compounds 2 and 3 (each within the scatter of the next).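

In this assay, (ethylamino)methyl in place of 1-(methylamino)butyl on this saturated ring carbon gives a 1.2-fold higher number from compound 2 to compound 3 (0.08 log units; within the scatter), so the substituent can go from 6 heavy atoms to 4, and lose its defined stereocentre, with no change that can be told from the scatter. The same group in place of 1-aminobutyl gives a 2.4-fold higher number from compound 1 to compound 3 (0.39 log units; beyond the scatter), a modest step. No evidence is available to explain either step.

Because chain length and the substituent on nitrogen change together in these steps, the compounds shown do not separate the two, and (methylamino)methyl or 1-(ethylamino)butyl at this ring carbon would be needed to do so. Also open, going by these compounds, is how an aminomethyl group or a longer chain would read here.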